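The source may hold more compounds than are shown below. What is called first, only, known or untested is meant among the compounds shown, and "the series" means these compounds.

Measured compounds: compound 1 `CC1=C(C(=O)OC(C)(C)C)C(c2cccs2)NC(=O)N1` with 7%; compound 2 `CC1=C(C(=O)OCC(C)C)C(c2ccco2)NC(=S)N1` with 10%.

In an assay on membranes from HeLa cells for displacement of a labelled ligand from adenosine receptor A3 (Homo sapiens), read by scintillation counting, with a stated time of 180 min, tested at 1 uM (on this read-out higher numbers stand for more inhibition at the one concentration tested (going by the name of the read-out) and lower numbers for less inhibition), compound 2 gives the higher of the two numbers, though its value and that of compound 1 lie within the scatter of each other, so neither stands apart. Compound 3 `CC1=C(C(=O)OCc2ccccc2)C(c2ccco2)NC(=S)N1` differs from compound 2 by phenyl in place of isopropyl on a saturated chain carbon bound to an oxygen next to a carbonyl group. Among the compounds with values here, no step between measured compounds is known here, so the size of this change cannot be read from anything measured. Compound 3 is expected to stay near compound 2, with the step of a number 2 percentage points higher from compound 2 to compound 3 (within the scatter) estimated to lie within the scatter and in no clear direction. For compound 3 the estimated value is 12%, with a range from 0% to 30%.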

Compound 3, a percentage reported as inhibition, at one concentration (the size of the read-out at that concentration, not a potency): 4%
Beside the measured number, compound 3's estimate is 8 percentage points above it; low and high end bracket the measured number.
By their numbers in this assay, from the lowest: compounds 3, 1 and 2 (each within the scatter of the next).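

In this assay this ester side chain now has its first readable step: phenyl in place of isopropyl on a saturated chain carbon bound to an oxygen next to a carbonyl group gives a number 6 percentage points lower from compound 2 to compound 3 (within the scatter) and so does not separate the two compounds. Isobutyl and benzyl therefore cannot be told apart here at the one concentration tested. No evidence at hand bears on this result.

As far as these compounds go, whether any group at this place can move the number beyond the scatter stays open. A longer chain in place of isobutyl, or an amine or a carboxylic acid on the benzyl group, would address this.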